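The source may hold more compounds than are shown below. What is called first, only, known or untested is meant among the compounds shown, and "the series" means these compounds.

For the measured compounds named here, in a functional assay on RAW264.7 cells (Mus musculus) for inhibition, with stated times of 2 h and 24 h (a higher number here means a weaker inhibitor, a lower number a stronger inhibitor), compound 3 `COc1ccc(CSC2c3cc(OC)cc(OC)c3[C@@H](c3ccc(OC)cc3)[C@@H]2c2cc(OC)cc(OC)c2)cc1` gives 12500 nM, the only true number among the compounds tested so far. Compound 1 `COc1ccc(/C=C2/c3cc(OC)cc(OC)c3[C@@H](c3ccccc3)[C@@H]2c2cc(OC)cc(OC)c2)cc1` gives > 200000 nM, which is a limit of the assay and not a number. Compound 2 `COc1cc(OC)cc([C@@H]2C(O)c3cc(OC)cc(OC)c3[C@H]2c2ccc(F)cc2)c1` is reported as "not active" (no number reported). No two of these compounds differ in just one place, so no measured step is available as a guide.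

Compound 4 `COc1ccc([C@@H]2c3c(OC)cc(OC)cc3C(C(O)c3ccccc3)[C@H]2c2cc(OC)cc(OC)c2)cc1`, still to be measured, differs from compound 3 in one place: hydroxy(phenyl)methyl in place of (4-methoxybenzyl)sulfanyl on a saturated ring carbon. Compound 1 and compound 2 also lack the (4-methoxybenzyl)sulfanyl group, and neither gave a number, so only the direction can be judged from them, and only loosely. A weaker inhibitor is therefore expected, by a moderate margin beyond the scatter, and the expected change is a 2.8-fold higher number from compound 3 to compound 4 (0.45 log units; beyond the scatter). For compound 4 the estimated value is 35000 nM, with an expected range of 10000 nM to 150000 nM.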

Compound 4, half-maximal inhibitory concentration: > 200000 nM
Compound 4 gave a limit, no number; the forecaster's own chance of this, stated with the estimate: 35%; middle value at least 5.7-fold (0.75 log units) away from the limit.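

In this assay, replacing (4-methoxybenzyl)sulfanyl with hydroxy(phenyl)methyl on this saturated ring carbon gives an at least 16-fold higher number from compound 3 to compound 4 (1.20 log units; beyond the scatter), the first direct one-place comparison available for this position. Both groups carry one six-membered aromatic ring of carbon only, so such a ring at this position is not enough on its own to give compound 4 a measurable value. The result for compound 4 is a limit of the assay and not a number, so the step gives only a minimum size: the limit of > 200000 nM in this assay, at which 2 of the 4 values shown sit.

The change swaps the sulfur, the methoxy group and the link to the aromatic ring all at once, so the compounds shown leave open which of these parts matters. Going by these compounds, it also remains open whether a benzylsulfanyl group without the methoxy, or an amine on this ring carbon, would give a number in this assay.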